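Pyrimidine core series: fluoro to hydroxy on the aryl

The source may hold more compounds than are shown below. What is called first, only, known or untested is meant among the compounds shown, and "the series" means these compounds.

Among the compounds with values here, compound 2 `Cn1c(-c2ccc(F)cc2)nc2c(NC3CCCC3)ncnc21` gives 32 nM in a functional assay on CHO cells for antagonist activity at adenosine receptor A1 (Homo sapiens), read by cAMP accumulation, with a stated time of 10 min (a lower number here means a stronger inhibitor, a higher number a weaker inhibitor), the highest of the two numbers so far; compound 1 `CCCC1CCC(CCC)(n2c(=O)[nH]c3nc[nH]c3c2=O)C1` gives 2.9 nM in this assay, a lower number, and the two differ in more than one place, so only the two values can be set side by side. Compound 3 `Cn1c(-c2ccc(O)cc2)nc2c(NC3CCCC3)ncnc21` carries the change (hydroxy in place of fluoro on an aromatic carbon), hydroxy in place of fluoro on an aromatic carbon. Within the data shown here, with no comparable step measured, the expected step from compound 2 to compound 3 is a 1.3-fold higher number from compound 2 to compound 3 (0.10 log units; within the scatter), not beyond the scatter in either direction. Compound 3 is therefore estimated at 40 nM, within 10 nM to 160 nM.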

Compound 3, half-maximal inhibitory concentration: 52 nM
Beside the measured number, compound 3's estimate is 1.3-fold (0.11 log units) below it; measured number inside the range.
By their numbers in this assay, from the lowest: compound 1; then compounds 2 and 3 (each within the scatter of the next).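

In this assay, the first step read at this position is a 1.6-fold higher number from compound 2 to compound 3 (0.21 log units; within the scatter), so 4-fluorophenyl and 4-hydroxyphenyl cannot be told apart here. The position therefore accepts a hydroxy, with its hydrogen-bond donor and acceptor, in place of fluoro without a step beyond the scatter. No supporting data bear on why the two compounds read alike. Still open, going by these compounds, is how an amine, a methoxy group or a carboxylic acid would read at this position on the shared core. Also open, on these data alone, is whether the same exchange reads alike on the core of compound 1.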